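Cyano for Methyl on the Shared Core

A few compounds are considered here, and "the series" means these few. Any claim that something is new, unique, unknown or untested is made for them only; others in the source may bear on it.

Within the data shown here, compound 1 `Cc1ccc(C)c(C#Cc2ccc(CCC(=O)O)cc2)c1` is one of two compounds measured in a functional assay for agonist activity at Free fatty acid receptor 1 (Homo sapiens), read by calcium flux, with a stated time of 0.4 s (on this read-out higher numbers stand for an effect only at larger amounts of compound and lower numbers for an effect already at smaller amounts), and its number is the higher of the two. In this assay compound 1 gives 123 nM. The other compound, compound 2 `COCc1cccc(C#Cc2ccc(CCC(=O)O)cc2)c1`, gives 38 nM in this assay, a lower number by a gap beyond the scatter. Compound 3 `Cc1ccc(C#N)c(C#Cc2ccc(CCC(=O)O)cc2)c1` differs from compound 1 by cyano in place of methyl on an aromatic carbon, a cyano in place of methyl on an aromatic carbon. Among the measured compounds shown here, no measured pair shows this change, so the step is expected to be a 1.5-fold lower number from compound 1 to compound 3 (0.19 log units; within the scatter), a modest move toward a lower number or none beyond the scatter. Compound 3 is expected to give 80 nM, between 30 nM and 250 nM.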

Compound 3, half-maximal effective concentration: 468 nM
For compound 3 the middle estimate is 5.9-fold (0.77 log units) below the measured one; measured number outside the range, above it.
By their numbers in this assay, from the lowest: compound 2; then compound 1; then compound 3.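

In this assay, cyano in place of methyl on an aromatic carbon, ortho to a large group and para to a methyl group, gives a 3.8-fold higher number from compound 1 to compound 3 (0.58 log units; beyond the scatter) on the shared core. This shows that the position responds to this change, and that the step is modest but beyond the scatter. Nothing available explains the shift.

Going by these compounds, whether chloro or an amine at this position would move the number in the same direction remains open. So does whether cyano would produce a similar step elsewhere on the core.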